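A few compounds are considered here, and "the series" means these few. Any claim that something is new, unique, unknown or untested is made for them only; others in the source may bear on it.

In a functional assay on HepG2 cells (Homo sapiens) for inhibition, read by MTT assay, with a stated time of 48 h (on this read-out higher numbers stand for weaker inhibition and lower numbers for stronger inhibition), compound 1 `COc1cccc(/C=C/C(=O)c2cc(OC)c(OC)c(OC)c2)c1OC` gives 11500 nM. Compound 2 `COc1cc(C(=O)/C=C/c2ccc(O)cc2)cc(OC)c1OC` gives 16000 nM, which lies within the scatter of the value for compound 1. For compound 3 `COc1cc(/C=C/C(=O)c2cc(OC)c(OC)c(OC)c2)ccc1O` the assay reports a limit and not a number, > 100000 nM.

The change under consideration leads from compound 1 to compound 4 `COc1cccc(/C=C/C(=O)c2cc(OC)c(OC)c(OC)c2)c1O`: hydrogen in place of methyl on an oxygen on an aromatic ring. This is hydrogen in place of methyl on an oxygen on an aromatic ring, or methoxy to hydroxy. For the measured compounds named here, no measured step makes exactly this change. The closest evidence is an at least 6.2-fold higher number from compound 2 to compound 3 (0.79 log units; beyond the scatter), a step with methoxy in place of hydrogen on an aromatic carbon, which ends at a compound carrying both hydroxy and methoxy on one ring, as compound 4 does. Against this, compound 2 also carries a hydroxy, and its 16000 nM lies within the scatter of compound 1. A modest move towards a higher number in this assay is therefore expected, estimated as a 2.6-fold higher number from compound 1 to compound 4 (0.42 log units; beyond the scatter). For compound 4 the expected value is 30000 nM, with an estimated range from 8000 nM to 100000 nM.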

Compound 4, half-maximal inhibitory concentration: 13500 nM
For compound 4 the middle estimate is 2.2-fold (0.35 log units) above the measured one, and the stated range covers the measured number.
By their numbers in this assay, from the lowest: compounds 1, 4 and 2 (each within the scatter of the next). At a limit, above all of these: compound 3.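

In this assay, the change from methoxy to hydroxy at this position is now measured directly and gives a 1.2-fold higher number from compound 1 to compound 4 (0.07 log units; within the scatter). The earlier compounds shown here offered only a step of another kind, methoxy in place of hydrogen on an aromatic carbon, whereas this step shows that the methyl on this oxygen can be replaced by hydrogen without a difference beyond the scatter. Compound 4 also shows that hydroxy and methoxy on one ring can go with a value close to that of compound 1, and compound 3, which carries both as well, goes against any wider pattern.

From the compounds shown here alone, compound 3 remains a limit and not a number, so its distance from the others stays open: the limit of > 100000 nM in this assay, at which 1 of the 4 values shown sits. Also open is how an amine or a longer chain such as ethoxy would read at this place.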